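Sulfamide-bearing piperidinyl pyrimidines: methyl on the phenyl ring

A few compounds are considered here, and "the series" means these few. Any claim that something is new, unique, unknown or untested is made for them only; others in the source may bear on it.

Two compounds of this series carry numbers. Compound 1 `Cc1ccc(-c2cc(N3CCC(CNS(N)(=O)=O)CC3)ncn2)cc1` in a functional assay on HT-29 cells (Homo sapiens) for antiproliferative activity, read by sulforhodamine B assay, with a stated time of 48 h (a higher number here means a weaker inhibitor of growth, a lower number a stronger inhibitor of growth), gives 33900 nM. Compound 2 `NS(=O)(=O)NCCC1CCN(c2cc(-c3ccccc3)ncn2)CC1` in this assay gives 66500 nM, the highest of the two numbers; compound 1 is its nearest neighbour, and the gap between them lies within the scatter. The two differ in more than one place, so the pair on its own shows only that both sit in the same weak region.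

Compound 3 `Cc1ccc(-c2cc(N3CCC(CCNS(N)(=O)=O)CC3)ncn2)cc1` differs from compound 2 in one place: methyl in place of hydrogen on an aromatic carbon. Among the compounds with values here, no step between measured compounds isolates this change. From the closeness of compound 1 at 33900 nM to compound 2, the step of a 1.5-fold lower number from compound 2 to compound 3 (0.17 log units; within the scatter) is expected to stay within the scatter, with at most a slight lowering. Compound 3 is therefore estimated at 45000 nM, with a range from 15000 nM to 130000 nM.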

Compound 3, concentration for 50% growth inhibition: 52300 nM
Beside the measured number, compound 3's estimate is 1.2-fold (0.07 log units) below it; the measured number falls inside the stated range.
By their numbers in this assay, from the lowest: compounds 1, 3 and 2 (each within the scatter of the next).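

The change from phenyl to 4-methylphenyl, on an aromatic carbon para to a large group, can now be read on its own in this assay (a 1.3-fold lower number from compound 2 to compound 3 (0.10 log units; within the scatter)). Compound 1 and compound 3 share the 4-methylphenyl group and differ only on the chain, where (sulfamoylamino)methyl stands in place of sulfamoylamino (a 1.5-fold higher number from compound 1 to compound 3 (0.19 log units; within the scatter)). Neither single change therefore moves the number beyond the scatter, so both the methyl and the chain difference leave these compounds in the same weak region, and no measurement on hand offers an explanation for either step.

From the compounds shown here alone, whether an amine or a carboxylic acid at this aromatic carbon would move the number beyond the scatter stays open. So does the outcome of a longer chain carrying the sulfamoylamino group.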